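The source may hold more compounds than are shown below. What is called first, only, known or untested is meant among the compounds shown, and "the series" means these compounds.

Among the compounds with values here, in an ADME assay on the whole organism for metabolic stability, with Rattus norvegicus as the target (on this read-out higher numbers stand for a longer-lived compound and lower numbers for a shorter-lived compound), compound 1 `CC(C)S(=O)(=O)n1cc2c(n1)CN([C@H]1CO[C@H](c3cc(F)ccc3F)[C@@H](N)C1)C2` gives 1.3 h and compound 2 `CCC(=O)Nc1n[nH]c2c1CN([C@H]1CO[C@H](c3cc(F)ccc3F)[C@@H](N)C1)C2` gives 2.2 h as the only numbers so far. The two lie within the scatter of each other, so the read-out does not separate compound 2 from compound 1.

Compound 3 `N[C@H]1C[C@@H](N2Cc3[nH]nc(NS(=O)(=O)C4CC4)c3C2)CO[C@@H]1c1cc(F)ccc1F` has not yet been measured. Its difference from compound 2 is cyclopropylsulfonyl in place of propanoyl on a nitrogen on an aromatic ring and amounts to cyclopropylsulfonyl in place of propanoyl on a nitrogen on an aromatic ring, or propanoylamino to (cyclopropylsulfonyl)amino when cut one bond further out.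

Within the data shown here, no measured pair differs in one place only, so nothing shows directly how this assay responds to this change. With compound 2 at 2.2 h as the starting point and compound 1 at 1.3 h within the scatter of it, no shift beyond the scatter is expected in either direction. The estimated 1.2-fold lower number from compound 2 to compound 3 (0.06 log units; within the scatter) is small and stays inside the scatter. The estimate for compound 3 is 1.9 h with an expected range from 1 h to 3.6 h for the coming measurement.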

Compound 3, half-life: 1.5 h
Estimate against measurement, compound 3: 1.3-fold (0.10 log units) above; measured number inside the range.
By their numbers in this assay, from the lowest: compounds 1, 3 and 2 (each within the scatter of the next).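

In this assay, within the data shown here, the only single-place step reads a 1.5-fold lower number from compound 2 to compound 3 (0.17 log units; within the scatter), so cyclopropylsulfonyl in place of propanoyl on a nitrogen on an aromatic ring gives no separation between the two compounds. This position therefore accepts a group of 6 heavy atoms with a three-membered ring in place of one of 4 heavy atoms with no ring, and the read-out shows no shift beyond the scatter. No measured property of either group is at hand to bear on this result.

One step with two groups says little about how far this tolerance extends, and compound 1 differs from compound 3 in more than one place, so it adds nothing to the reading of this position. From the compounds shown here alone, whether a free amine, a longer chain on the carbonyl or a methyl on the sulfonyl at this nitrogen would move the number in this assay beyond the scatter remains open.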